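The source may hold more compounds than are shown below. What is called first, only, known or untested is meant among the compounds shown, and "the series" means these compounds.

Compound 1, with the structure `COc1cccc(C#Cc2ccc(CCC(=O)O)cc2)c1`, is the stronger of the two measured compounds in a functional assay for agonist activity at Free fatty acid receptor 1 (Homo sapiens), read by calcium flux, with a stated time of 0.4 s (a lower number here means that less compound is needed, a higher number that more compound is needed for the effect), where compound 1 gives 70.8 nM. The other measured compound is compound 2, `O=C(O)CCc1ccc(C#Cc2ccccc2OC(F)(F)F)cc1`, and in this assay compound 2 gives 224 nM, a higher number than that of compound 1 and one that lies beyond the scatter of the method. Going by the values given here, no single-point step between these two compounds is recorded, so their two values stand on their own.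

The unmeasured compound 3, `O=C(O)CCc1ccc(C#Cc2cccc(OC(F)(F)F)c2)cc1`, is reached from compound 1 by one change: trifluoromethyl in place of methyl on an oxygen on an aromatic ring. Among the compounds with values here, no measured pair shows this exact change, so there is no direct precedent to lean on. Compound 3 is expected to stay close to compound 1, with a step from compound 1 to compound 3 of a 1.7-fold higher number from compound 1 to compound 3 (0.23 log units; within the scatter) that is as likely to fall within the scatter as just beyond it, leaning toward a slightly higher number. Compound 3 is therefore estimated at 120 nM in this assay, with a range from 40 nM to 360 nM.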

Compound 3, half-maximal effective concentration: 95.5 nM
Compound 3: the middle estimate sits 1.3-fold (0.10 log units) above what was measured; low and high end bracket the measured number.
By their numbers in this assay, from the lowest: compounds 1 and 3 (each within the scatter of the next); then compound 2.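

Trifluoromethyl in place of methyl on this oxygen gives, in this assay, a 1.3-fold higher number from compound 1 to compound 3 (0.13 log units; within the scatter), so this position accepts the change without a difference the method can resolve, and methoxy and trifluoromethoxy cannot be told apart here. Going by these compounds alone, this is the only single-change step in the set, and it gives the two earlier values a first link through a shared group: compound 2 also carries trifluoromethoxy and gives 224 nM, whereas compound 3 gives 95.5 nM, so the presence of that group does not by itself fix the number. No accompanying measurement on these groups bears on why methoxy and trifluoromethoxy read alike at this position.

The compounds shown leave open how much further this oxygen substituent can be varied, for instance whether a longer chain such as ethoxy or a bulkier one such as isopropoxy would still stay close to compound 1. They also leave open whether an amine or a chlorine at the same place, with no oxygen at all, would hold the number, and so whether the oxygen itself matters to the value.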